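Replacing isopropyl with 4-methoxycyclohexyl on the shared core

The source may hold more compounds than are shown below. What is called first, only, known or untested is meant among the compounds shown, and "the series" means these compounds.

Measured in an in vitro ADME assay on microsomes (Mus musculus) for metabolic stability; a lower number here means that the compound disappears faster, a higher number that the compound lasts longer:
- Compound 1 `CNC(=O)Nc1ccc(-c2nc(N3CC4CCC(C3)O4)c3cnn(C(C)C)c3n2)cc1`: > 0.5 h
- Compound 2 `O=C(Nc1ccc(-c2nc(N3CC4CCC(C3)O4)c3cnn(C4CCC5(CC4)OCCO5)c3n2)cc1)Nc1cccnc1`: > 0.5 h

Compound 1 stands at > 0.5 h, which is a limit of the assay and not a number. Compound 2 gives > 0.5 h, which is also a limit. Neither compound therefore has an exact half-life, and the evidence so far amounts to the limit of > 0.5 h in this assay, at which 2 of the 2 values shown sit.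

Compound 3 `CNC(=O)Nc1ccc(-c2nc(N3CC4CCC(C3)O4)c3cnn([C@H]4CC[C@@H](OC)CC4)c3n2)cc1` keeps the core of compound 1 but carries 4-methoxycyclohexyl in place of isopropyl on an aromatic nitrogen. Among the measured compounds shown here, no measured pair isolates this change, so the expectation in this assay rests on the structural change alone. The expected step, an at least 1.2-fold lower number from compound 1 to compound 3 (0.09 log units; that floor lies within the scatter), points towards a shorter half-life and is of modest size, close to the scatter. Another result reported only as a limit remains quite possible. For compound 3 the estimated half-life is 0.4 h, with an expected range from 0.15 h to 0.8 h.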

Compound 3, half-life: 0.283 h
The estimate for compound 3 lay 1.4-fold (0.15 log units) above the measured number; measured number inside the range.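

In this assay compound 3 gives 0.283 h, the only exact half-life among the compounds shown. Compound 1 stands at > 0.5 h, which is a limit of the assay and not a number. The change on the aromatic nitrogen, 4-methoxycyclohexyl in place of isopropyl, gives an at least 1.7-fold lower number from compound 1 to compound 3 (0.24 log units; that floor lies within the scatter), so this position now has a readable number, but the step is known only as a floor and the other values remain at a limit: the limit of > 0.5 h in this assay, at which 2 of the 3 values shown sit.

The compounds shown leave open whether the lower number goes with the cyclohexyl ring or with its methoxy group. They also leave open how a plain cyclohexyl, a 4-hydroxycyclohexyl or the other stereoisomer of 4-methoxycyclohexyl on the same nitrogen would read in this assay.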